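The source may hold more compounds than are shown below. What is called first, only, known or untested is meant among the compounds shown, and "the series" means these compounds.

Among the measured compounds shown here, compound 1, `COc1cccc(NC(=O)COc2cc(C)nc3ccc(OC)cc23)c1`, is the only member of this small set with a definite number in an ADME assay on HepG2 cells (Homo sapiens) for cytotoxicity, read by trypan blue exclusion, with a stated time of 48 h, in the presence of a further agent that is not named here; on this read-out higher numbers stand for lower toxicity in this test and lower numbers for higher toxicity in this test: compound 1 gives 43000 nM. Compound 2, `COc1cc(NC(=O)COc2cc(C)nc3ccc(OC)cc23)cc(OC)c1`, reaches only a limit of the assay, > 131000 nM. Compound 3, `COc1ccc2nc(C)cc(OCC(=O)Nc3ccc(C)cc3)c2c1`, likewise reaches only a limit of the assay, > 149000 nM. Both changes made to compound 1 so far therefore moved the number up: an at least 3.0-fold higher number from compound 1 to compound 2 (0.48 log units; beyond the scatter) and an at least 3.4-fold higher number from compound 1 to compound 3 (0.53 log units; beyond the scatter), each ending at a limit rather than a number, as noted in the limit of > 131000 nM in this assay, at which 1 of the 3 values shown sits, and (the limit of > 149000 nM in this assay, at which 1 of the 3 values shown sits).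

Compound 4, `CCCCCNC(=O)COc1cc(C)nc2ccc(OC)cc12`, is not yet measured. It differs from compound 1 by pentyl in place of 3-methoxyphenyl on an amide-type nitrogen. For the measured compounds named here, of the measured steps, the one from compound 1 to compound 3 is the closer parallel, since it also replaces the group on the amide-type nitrogen, and it gave an at least modest rise; the step from compound 1 to compound 2 adds weight to the same direction. A pentyl group is a larger departure than either, so the direction is less secure. The expectation for compound 4 is a modest step upward, a 2.1-fold higher number from compound 1 to compound 4 (0.32 log units; beyond the scatter), with a fair chance that only a limit is returned. The estimated value for compound 4 is 90000 nM, within 30000 nM to 200000 nM.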

Compound 4, half-maximal cytotoxic concentration: > 158000 nM
Compound 4 gave a limit, no number; the forecaster's own chance of this, stated with the estimate: 40%; middle value at least 1.7-fold (0.24 log units) away from the limit.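

Pentyl in place of 3-methoxyphenyl on the amide-type nitrogen gives an at least 3.6-fold higher number from compound 1 to compound 4 (0.56 log units; beyond the scatter), so in this assay the rise at this place does not need an aromatic ring, which compound 3 still carried. Compound 4 returns a limit, not a number: the limit of > 158000 nM in this assay, at which 1 of the 4 values shown sits.

The step from compound 3 to compound 4 joins two limits and cannot be read, so pentyl and 4-methylphenyl remain unranked.

Among the compounds shown here, compound 1 stays the only compound with a definite number, so it remains open which groups on this nitrogen give a definite number at all. A shorter chain such as ethyl, or a pentyl chain ending in an amine or a carboxylic acid, would show whether the number stays at a limit.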